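Trimming One Side Chain on a Cytotoxic Compound

The compounds below may be only part of what the source reports. "The series", "measured", "known", "first", "only" and "open" are said of these compounds alone.

compound 1 `CC(C)CC1NC(=O)N(OCc2ccc(Br)cc2)C1=O`: 150 nM
compound 2 `CC(C)CC1NC(=O)N(OCc2cccc(Cl)c2)C1=O`: 40 nM

In a functional assay on HEp-2 cells (Homo sapiens) for cytotoxicity, read by MTT assay (a lower number here means a stronger inhibitor, a higher number a weaker inhibitor), compound 2 gives the lower of the two numbers (40 nM) and so stands as the stronger inhibitor, with compound 1 at 150 nM, a gap beyond the usual scatter. The next compound, compound 3 `CC(C)C1NC(=O)N(OCc2cccc(Cl)c2)C1=O`, keeps the shared core but carries isopropyl in place of isobutyl on a saturated ring carbon. Among the compounds with values here, no measured pair tests this change, so the data give no direct guide. A modest move toward a higher number, about the size of the scatter, is expected in this assay, meaning a somewhat weaker inhibitor. The estimated step is a 2.0-fold higher number from compound 2 to compound 3 (0.30 log units; within the scatter) and no more than a rough expectation. For compound 3 the expected value is 80 nM ( estimated range 20 nM to 300 nM)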

Compound 3, half-maximal inhibitory concentration: 70 nM
Beside the measured number, compound 3's estimate is 1.1-fold (0.06 log units) above it; the range from low to high includes it.
By their numbers in this assay, from the lowest: compounds 2 and 3 (each within the scatter of the next); then compound 1.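

In this assay, isopropyl in place of isobutyl on a saturated ring carbon gives a 1.8-fold higher number from compound 2 to compound 3 (0.24 log units; within the scatter). Within the data shown here, this pair offers the first direct reading at this position, since compound 1 and compound 2 both carry isobutyl there, and it shows that removing one carbon from this side chain leaves a difference too small to separate from ordinary repeat-to-repeat variation. Nothing in the available data speaks to the reason for this result.

With only these two small branched chains compared at this position, a single pair cannot show how much the group there can change before the number clearly moves. As far as these compounds go, a longer chain such as n-hexyl, a phenyl ring or an amine on the same carbon could behave quite differently, so the wider trend remains open.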